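The source may hold more compounds than are shown below. What is called first, only, known or untested is meant among the compounds shown, and "the series" means these compounds.

Within the data shown here, in an assay on JEG-3 cells for inhibition of Aromatase (Homo sapiens), with a stated time of 1 h (a lower number here means a stronger inhibitor, a higher number a weaker inhibitor), compound 2 `CC#CCOc1ccc2cc(C(c3ccc(Cl)cc3)n3cncn3)oc2c1` gives 0.53 nM, the lowest of the two numbers so far; compound 1 `CCC#CCOc1ccc2cc(C(c3ccc(Cl)cc3)n3cncn3)oc2c1` gives 2.76 nM. Across that pair, a 5.2-fold lower number from compound 1 to compound 2 (0.72 log units; beyond the scatter), the only measured step. Compound 3 `CCOc1ccc2cc(C(c3ccc(Cl)cc3)n3cncn3)oc2c1` carries the same change one bond further in: methyl in place of prop-1-yn-1-yl on a saturated chain carbon bound to an oxygen on an aromatic ring. Among the measured compounds shown here, the measured step points toward shorter chains, but this cut removes the triple bond itself, which no measured pair tests, so only a small to modest drift is expected in this assay, more likely upward. For compound 3 the expected step is a 2.8-fold higher number from compound 2 to compound 3 (0.45 log units; beyond the scatter). Compound 3 is thus estimated at 1.5 nM, range 0.4 nM to 6 nM.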

Compound 3, half-maximal inhibitory concentration: 0.46 nM
Estimate against measurement, compound 3: 3.3-fold (0.51 log units) above; measured number inside the range.
By their numbers in this assay, from the lowest: compounds 3 and 2 (each within the scatter of the next); then compound 1.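

In this assay, the triple bond is not required at this position: replacing prop-1-yn-1-yl with methyl gives a 1.2-fold lower number from compound 2 to compound 3 (0.06 log units; within the scatter). Chain length on the oxygen still matters within this set, since the but-1-yn-1-yl to methyl change gives a 6.0-fold lower number from compound 1 to compound 3 (0.78 log units; beyond the scatter). No measured evidence bears on the reason for either result.

The compounds shown do not separate length from the triple bond in compound 1, so a saturated longer chain such as butoxy could fall with either compound 1 or compound 3. On these data alone, how an amine or a carboxylic acid on this chain would read also remains open.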